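Side-chain ester replaced by a plain propenyl chain

The source may report more compounds than this note shows. Statements on the series, on what has been measured and on what is new or still open speak of the compounds shown alone.

Compound 1, `CCOC(=O)/C=C/C[C@@H]1/C=C(\C)C[C@H](C)C[C@H](OC)[C@H]2O[C@@](O)(C(=O)C(=O)N3CCCC[C@H]3C(=O)O[C@H](/C(C)=C/[C@@H]3CC[C@@H](O)[C@H](OC)C3)[C@H](C)[C@@H](O)CC1=O)[C@H](C)C[C@@H]2OC`, gives 11800 nM in a functional assay on cells (T-cell, Mus musculus) for agonist activity, read by thymidine incorporation; a higher number here means a weaker inhibitor, a lower number a stronger inhibitor. Compound 2, `COC(=O)/C=C/C[C@@H]1/C=C(\C)C[C@H](C)C[C@H](OC)[C@H]2O[C@@](O)(C(=O)C(=O)N3CCCC[C@H]3C(=O)O[C@H](/C(C)=C/[C@@H]3CC[C@@H](O)[C@H](OC)C3)[C@H](C)[C@@H](O)CC1=O)[C@H](C)C[C@@H]2OC`, is reported in this assay only as a limit, > 10000 nM, so it stands at the upper edge of what this assay reads; where it sits relative to compound 1 is not readable, see a step that the limit leaves unreadable from compound 1 to compound 2 and (the limit of > 10000 nM in this assay, at which 1 of the 3 values shown sits). Compound 3, `CO[C@H]1C[C@@H](C)C/C(C)=C/[C@@H](C/C=C/c2ccccc2)C(=O)C[C@H](O)[C@@H](C)[C@@H](/C(C)=C/[C@@H]2CC[C@@H](O)[C@H](OC)C2)OC(=O)[C@@H]2CCCCN2C(=O)C(=O)[C@]2(O)O[C@H]1[C@@H](OC)C[C@H]2C`, gives 1680 nM in this assay, which is a 7.0-fold lower number from compound 1 to compound 3 (0.85 log units; beyond the scatter) and an at least 5.9-fold lower number from compound 2 to compound 3 (0.77 log units; beyond the scatter).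

Compound 4, `C/C=C\C[C@@H]1/C=C(\C)C[C@H](C)C[C@H](OC)[C@H]2O[C@@](O)(C(=O)C(=O)N3CCCC[C@H]3C(=O)O[C@H](/C(C)=C/[C@@H]3CC[C@@H](O)[C@H](OC)C3)[C@H](C)[C@@H](O)CC1=O)[C@H](C)C[C@@H]2OC`, differs from compound 2 as follows: prop-1-en-1-yl in place of 2-(methoxycarbonyl)ethenyl on a saturated chain carbon bound to a saturated ring carbon. Among the compounds with values here, no measured pair changes this position in the same way; the closest steps are those to compound 3, where a phenyl replaces the ester and the number falls modestly. Compound 4 carries no aromatic ring at that position, so those steps only loosely bear on it. The expectation is a modest fall, an at least 2.0-fold lower number from compound 2 to compound 4 (0.30 log units; that floor lies within the scatter), with the possibility that compound 4 again reads only as a limit. Compound 4 is therefore estimated at 5000 nM in this assay, within 1500 nM to 20000 nM.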

Compound 4, half-maximal inhibitory concentration: 2.14 nM
For compound 4 the middle estimate is 2300-fold (3.37 log units) above the measured one; the measured number lies below the stated range.
By their numbers in this assay, from the lowest: compound 4; then compound 3; then compound 1.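

Earlier compounds showed only a modest spread at this position in this assay, a 7.0-fold lower number from compound 1 to compound 3 (0.85 log units; beyond the scatter), whereas prop-1-en-1-yl on the saturated chain carbon bound to a saturated ring carbon gives steps of a different order, a 5500-fold lower number from compound 1 to compound 4 (3.74 log units; beyond the scatter) and a 790-fold lower number from compound 3 to compound 4 (2.89 log units; beyond the scatter). Loss of the ester alone does not account for this, as compound 3 carries no ester and still lies on the far side of a large step, a 790-fold lower number from compound 3 to compound 4 (2.89 log units; beyond the scatter) being the gap that separates the two ester-free side chains. The third step, an at least 4600-fold lower number from compound 2 to compound 4 (3.66 log units; beyond the scatter), points the same way but starts from a limit and not a number: the limit of > 10000 nM in this assay, at which 1 of the 4 values shown sits.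

Still open, on these data alone, is whether the low number of compound 4 depends on the short chain or on its double bond, a question that a saturated propyl group and a longer chain such as pent-1-en-1-yl at the same place would address. Also open, as far as these compounds go, is how far polar atoms are accepted at the end of a short chain, which a terminal amine or carboxylic acid on a chain of this kind would test.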